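Butyl on the triazole of an adenosine A3 ligand

This account rests on a few compounds, and the source may have more. Where it says the series, first, only, none or still open, it means among the compounds named here.

Measured so far:
compound 1 `CCNC(=O)[C@H]1O[C@@H](n2cnc3c(NC)nc(-n4ccnn4)nc32)[C@H](O)[C@@H]1O`: 2.1 nM
compound 2 `CNc1nc(-n2cc(CC3CCCCC3)nn2)nc2c1ncn2[C@@H]1O[C@H](CO)[C@@H](O)[C@H]1O`: 21.3 nM
compound 3 `CNc1nc(-n2cc(CC3CCCC3)nn2)nc2c1ncn2[C@@H]1O[C@H](CO)[C@@H](O)[C@H]1O`: 1.3 nM

In an assay on CHO cells for displacement of a labelled ligand from adenosine receptor A3 (Homo sapiens) (on this read-out lower numbers stand for stronger inhibition and higher numbers for weaker inhibition), compound 1 holds the second highest of the three numbers; compound 3 lies within the scatter of it, while compound 2 is beyond the scatter with a higher number. Compound 4 `CCCCc1cn(-c2nc(NC)c3ncn([C@@H]4O[C@H](C(=O)NCC)[C@@H](O)[C@H]4O)c3n2)nn1` differs from compound 1 by butyl in place of hydrogen on an aromatic carbon. For the measured compounds named here, no measured step changes exactly this position, but the one known step, a 16-fold lower number from compound 2 to compound 3 (1.21 log units; beyond the scatter), shows that the group on that triazole carbon can move this assay strongly. Since compound 3, carrying a ring group there, sits within the scatter of compound 1, the step of a 1.2-fold higher number from compound 1 to compound 4 (0.08 log units; within the scatter) is expected to be small. Compound 4 is therefore estimated at 2.5 nM, within 0.6 nM to 10 nM.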

Compound 4, inhibition constant: 5.6 nM
Estimate against measurement, compound 4: 2.2-fold (0.35 log units) below; measured number inside the range.
By their numbers in this assay, from the lowest: compounds 3 and 1 (each within the scatter of the next); then compound 4; then compound 2.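

In this assay, for the compounds shown here, placing butyl on the aromatic carbon of the triazole gives a 2.7-fold higher number from compound 1 to compound 4 (0.43 log units; beyond the scatter), the first direct reading at this position, and it shows that the open chain weakens inhibition modestly rather than abolishing it on the core of compound 1. Nothing available explains this shift.

The compounds shown leave open whether a shorter chain such as methyl, a longer chain such as octyl, or an amine at the end of the butyl would move the number further. Compound 2 and compound 3 differ from compound 4 in more than one place, so their ring groups cannot be set directly against butyl.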